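The source may report more compounds than this note shows. Statements on the series, on what has been measured and on what is new or still open speak of the compounds shown alone.

In a functional assay on SH-SY5Y cells (Homo sapiens) for cytotoxicity, read by MTT assay, with a stated time of 72 h (on this read-out lower numbers stand for stronger inhibition and higher numbers for weaker inhibition), compound 2 `O=C1c2c[n+]([O-])c3ccccc3c2C(=O)c2c1c1ccccc1n2CCN1CCCC1` gives 520 nM, the higher of the two exact numbers in this series. Compound 1 `O=C1c2c[n+]([O-])c3ccccc3c2C(=O)c2c1c1ccccc1n2Cc1cn([C@@H]2C[C@H](O)[C@@H](CO)O2)nn1` gives 150 nM, the lower of the two. Compound 3 `CC1(C)OC[C@@H](Cn2cc(Cn3c4c(c5ccccc53)C(=O)c3c[n+]([O-])c5ccccc5c3C4=O)nn2)O1` gives > 1000 nM, which is a limit of the assay and not a number.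

The next comparison is compound 4 `CN1CCN(CCCCCCn2c3c(c4ccccc42)C(=O)c2c[n+]([O-])c4ccccc4c2C3=O)CC1`, which has 4-(4-methylpiperazin-1-yl)butyl in place of pyrrolidin-1-yl on a saturated chain carbon, two bonds along the chain from an aromatic nitrogen.

Among the measured compounds shown here, no measured step covers this exchange. The closest guide is an at least 6.6-fold higher number from compound 1 to compound 3 (0.82 log units; beyond the scatter), which swaps 4-hydroxy-5-(hydroxymethyl)oxolan-2-yl for (2,2-dimethyl-1,3-dioxolan-4-yl)methyl on an aromatic nitrogen. For the measured compounds named here, that step shows that a change of side chain can shift this assay beyond the scatter, but it involves neither group exchanged here and gives no direction for this pair. The working expectation is therefore no step beyond the scatter, with a wide margin on either side. The estimated outcome is a 1.0-fold lower number from compound 2 to compound 4 (0.02 log units; within the scatter). A result reported as a limit also remains possible. For compound 4 the expected value is 500 nM, with an estimated range from 140 nM to 1600 nM.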

Compound 4, half-maximal inhibitory concentration: 920 nM
Estimate against measurement, compound 4: 1.8-fold (0.26 log units) below, and the stated range covers the measured number.
By their numbers in this assay, from the lowest: compound 1; then compounds 2 and 4 (each within the scatter of the next). At a limit, above all of these: compound 3.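

The exchange of pyrrolidin-1-yl for 4-(4-methylpiperazin-1-yl)butyl on a saturated chain carbon, two bonds along the chain from an aromatic nitrogen, gives a 1.8-fold higher number from compound 2 to compound 4 (0.25 log units; within the scatter) in this assay. Among the compounds shown here, the earlier compounds showed only that a side-chain exchange on an aromatic nitrogen can move this read-out beyond the scatter, whereas this first step at the chain position shows that a much larger group with a second ring nitrogen can enter without doing so. Compound 3 remains the only compound at a limit, which is not a number: the limit of > 1000 nM in this assay, at which 1 of the 4 values shown sits.

The step changes chain length and end group together, so the compounds shown do not separate the contribution of the butyl extension from that of the 4-methylpiperazin-1-yl ring, a question that pyrrolidin-1-yl on the longer chain or 4-methylpiperazin-1-yl on the shorter chain would address. Also open, from the compounds shown here alone, is how a morpholine, a primary amine or a carboxylic acid at the end of the chain would read in this assay.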